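Removing the trifluoromethyl group from compound 2

A few compounds are considered here, and "the series" means these few. Any claim that something is new, unique, unknown or untested is made for them only; others in the source may bear on it.

Compound 1 `COc1cc2ncnc(NNC(=S)NC(=O)c3ccc(C(F)(F)F)cc3)c2cc1OC` gives 16500 nM in a functional assay on CNE-2 cells (Homo sapiens) for cytotoxicity, read by MTT assay, with a stated time of 72 h; on this read-out lower numbers stand for stronger inhibition and higher numbers for weaker inhibition. Compound 2 `O=C(NC(=S)NNc1ncnc2ccccc12)c1ccc(C(F)(F)F)cc1` gives 22500 nM in this assay, the highest of the three numbers; compound 1 sits within the scatter of it, while compound 3 `COc1cc2ncnc(NNC(=S)NC(=O)c3ccc(Cl)cc3)c2cc1OC`, with 7530 nM, sits beyond it. Within the data shown here, the single measured one-place step, a 2.2-fold lower number from compound 1 to compound 3 (0.34 log units; beyond the scatter), chloro in place of trifluoromethyl on an aromatic carbon, is modest.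

Compound 4 `O=C(NC(=S)NNc1ncnc2ccccc12)c1ccccc1` differs from compound 2 by hydrogen in place of trifluoromethyl on an aromatic carbon. Among the measured compounds shown here, no measured step removes this group to hydrogen; the only related step, a 2.2-fold lower number from compound 1 to compound 3 (0.34 log units; beyond the scatter), exchanges it for another group, so a step of that size in either direction, or none beyond the scatter, is plausible. Compound 4 is therefore expected at 17000 nM, with a range from 7000 nM to 40000 nM. This estimate amounts to an expected 1.3-fold lower number from compound 2 to compound 4 (0.12 log units; within the scatter).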

Compound 4, half-maximal inhibitory concentration: 1490 nM
Compound 4: the middle estimate sits 11-fold (1.06 log units) above what was measured, and the stated range ends above it.
By their numbers in this assay, from the lowest: compound 4; then compound 3; then compounds 1 and 2 (each within the scatter of the next).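

In this assay hydrogen in place of trifluoromethyl gives a 15-fold lower number from compound 2 to compound 4 (1.18 log units; beyond the scatter) and so counts as a large step. This place on the aromatic ring, para to a large group, therefore responds far more strongly than the modest exchange in a 2.2-fold lower number from compound 1 to compound 3 (0.34 log units; beyond the scatter) had shown, and a substituent is not needed there for a low number. No measurement at hand accounts for the size of this step.

From the compounds shown here alone, whether hydrogen gives a step of similar size on the core of compound 1 remains open. Also open, going by these compounds, is how an amine, a carboxylic acid or a nitrile would behave at this place.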